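The source may report more compounds than this note shows. Statements on the series, on what has been measured and on what is new or still open speak of the compounds shown alone.

Measured so far in an in vitro ADME assay on microsomes from liver (Rattus norvegicus) for metabolic stability (a higher number here means faster removal of the compound, a lower number slower removal), are three compounds:
Compound 1 `CN1CC(=O)N/C1=N\C(=O)Nc1csc(Cl)c1` gives 27 mL.min-1.g-1
Compound 2 `CN1CC(=O)N/C1=N\C(=O)Nc1ccncc1` gives 9 mL.min-1.g-1
Compound 3 `CN1CC(=O)N/C1=N\C(=O)Nc1ccccn1` gives 22 mL.min-1.g-1

Compound 2 has the lowest number of the three, at 9 mL.min-1.g-1 in this assay, and both compound 3 and compound 1 lie above it by more than the scatter. Compound 4 `Cc1cnccc1NC(=O)/N=C1\NC(=O)CN1C` has not yet been measured. It keeps the core of compound 2 and differs from it in one place: methyl in place of hydrogen on an aromatic carbon, with methyl in place of hydrogen on an aromatic carbon, ortho to a large group and two atoms from the ring nitrogen.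

Within the data shown here, no two measured compounds differ in a single place, so the data hold no direct measure of what this change does, and the expectation remains loose. A small move towards a higher number is expected, one that may not clear the scatter. The estimated move is a 1.4-fold higher number from compound 2 to compound 4 (0.16 log units; within the scatter), and this is a modest step. The wide upper end of the range is a cautious allowance, as compound 1 at 27 mL.min-1.g-1 shows how high this small set reaches. For compound 4 the expected value is 13 mL.min-1.g-1, with an estimated range from 7 mL.min-1.g-1 to 26 mL.min-1.g-1 as the measurement is awaited.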

Compound 4, intrinsic clearance in microsomes: 14 mL.min-1.g-1
For compound 4 the middle estimate is 1.1-fold (0.03 log units) below the measured one; low and high end bracket the measured number.
By their numbers in this assay, from the lowest: compounds 2, 4, 3 and 1 (each within the scatter of the next, the first and the last beyond it).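

Among these compounds, the replacement of hydrogen by methyl gives the first direct reading of a single change in this set: in this assay, it amounts to a 1.6-fold higher number from compound 2 to compound 4 (0.19 log units; within the scatter). At this position, on an aromatic carbon ortho to a large group and two atoms from the ring nitrogen, one added carbon therefore leaves compound 4 indistinguishable from compound 2 in this read-out, so the position accepts a methyl without a step that clears the usual scatter. Nothing shown explains this outcome, and the reading rests on one pair of compounds and one small group.

The compounds shown leave open whether a larger or different group at this same position, such as an ethyl, a methoxy, a chlorine or an amine, would produce a step beyond the scatter, or whether the tolerance seen here is limited to methyl. From the compounds shown here alone, it also remains open whether a methyl on another aromatic carbon of this ring, or the same replacement on the ring of compound 1 or compound 3, would produce a step of similar size.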